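A few compounds are considered here, and "the series" means these few. Any claim that something is new, unique, unknown or untested is made for them only; others in the source may bear on it.

Measured so far in a functional assay on HCT-116 cells (Homo sapiens) for inhibition, read by MTT assay, with a stated time of 72 h; on this read-out higher numbers stand for weaker inhibition and lower numbers for stronger inhibition:
- compound 1 `COc1cc(Oc2cccc(Nc3ccccc3)c2)cc(OC)c1CNCc1ccc(F)cc1`: 4220 nM
- compound 2 `COc1cc(Oc2cccc(Nc3ccccc3)c2)cc(OC)c1CN(C)C`: 12900 nM
- compound 3 `COc1cc(Oc2cccc(Nc3ccccc3)c2)cc(OC)c1CNCc1ccc(O)cc1`: 3360 nM

For the measured compounds named here, compound 3 gives the lowest number of the three, though its gap to compound 1 stays within the scatter; only the step of a 3.8-fold lower number from compound 2 to compound 3 (0.58 log units; beyond the scatter) is beyond it. Compound 4 `COc1cc(Oc2cccc(Nc3ccccc3)c2)cc(OC)c1CNCc1ccc(Br)cc1` carries the change (bromo in place of hydroxy on an aromatic carbon). The step that bears on this position is a 1.3-fold lower number from compound 1 to compound 3 (0.10 log units; within the scatter), where swapping fluoro and hydroxy on the same aromatic carbon left the number within the scatter. The steps of a 3.1-fold higher number from compound 1 to compound 2 (0.49 log units; beyond the scatter) and a 3.8-fold lower number from compound 2 to compound 3 (0.58 log units; beyond the scatter) alter the amine substituent instead and say little here. A step of no size beyond the scatter is therefore expected, a 1.0-fold higher number from compound 3 to compound 4 (0.02 log units; within the scatter), with compound 4 estimated at 3500 nM in this assay, between 1500 nM and 8000 nM.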

Compound 4, half-maximal inhibitory concentration: 6230 nM
Compound 4: middle estimate off by 1.8-fold (0.25 log units), on the low side; the range from low to high includes it.
By their numbers in this assay, from the lowest: compounds 3, 1 and 4 (each within the scatter of the next); then compound 2.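

In this assay, bromo joins fluoro and hydroxy on this aromatic carbon with no separation beyond the scatter, showing a 1.9-fold higher number from compound 3 to compound 4 (0.27 log units; within the scatter) and a 1.5-fold higher number from compound 1 to compound 4 (0.17 log units; within the scatter). The gap to the dimethylamino compound also holds with bromo in place, at a 2.1-fold lower number from compound 2 to compound 4 (0.32 log units; beyond the scatter), so all three substituted benzylamines now stand apart from compound 2. No available evidence accounts for these numbers.

Open, from the compounds shown here alone, is whether an amino group or a carboxylic acid on this aromatic carbon would stay in the same range. Also open, going by these compounds, is how a longer chain in place of the benzyl group would read.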